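Trimming one methoxy from a growth-inhibiting diamine

The compounds below may be only part of what the source reports. "The series", "measured", "known", "first", "only" and "open" are said of these compounds alone.

Of the compounds shown here, two built on a shared core have been tested in a functional assay on HCC 2998 cells (Homo sapiens) for inhibition, read by sulforhodamine B assay, with a stated time of 48 h; on this read-out higher numbers stand for weaker inhibition of growth and lower numbers for stronger inhibition of growth. Compound 1 `CCOC(=O)[C@H](CCC(=O)O)NC(=O)c1ccc(CNc2nc3cc(N)cc(N)c3nc2-c2ccccc2)cc1` returned only a limit, recorded as < 100000 nM, which marks the edge of what this assay reports rather than a number. For the measured compounds named here, compound 2 `COc1ccc(CNc2nc3cc(N)cc(N)c3nc2-c2ccccc2)cc1OC` gives 22900 nM in this assay, and this is the only full number among the values shown, the other sitting at the limit of < 100000 nM in this assay, at which 1 of the 2 values shown sits. Compound 3 `COc1ccc(CNc2nc3cc(N)cc(N)c3nc2-c2ccccc2)cc1` has not yet been measured. It differs from compound 2 in one place: hydrogen in place of methoxy on an aromatic carbon, ortho to a methoxy group and meta to a large group. Going by the values given here, no measured pair shows what such a removal does here, so the step from compound 2 to compound 3 is expected to be small, a 1.2-fold higher number from compound 2 to compound 3 (0.09 log units; within the scatter), within or only just beyond the usual scatter. Compound 3 is therefore expected to give about 28000 nM in this assay, most likely between 9000 nM and 90000 nM.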

Compound 3, concentration for 50% growth inhibition: 21900 nM
Compound 3: the middle estimate sits 1.3-fold (0.11 log units) above what was measured; the measured number falls inside the stated range.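

For the compounds shown here, compound 3 supplies the first step on this core that can be read as a number, and it is a 1.0-fold lower number from compound 2 to compound 3 (0.02 log units; within the scatter) in this assay for a methoxy group ortho to a methoxy group and meta to a large group. Within the scatter of this read-out, then, the 3,4-dimethoxyphenyl and 4-methoxyphenyl compounds cannot be told apart, and growth inhibition at this level does not depend on that methoxy group. Nothing measured here accounts for this result.

This single pair does not show whether the remaining methoxy group matters, since both compounds carry it. Going by these compounds, whether a fluorine, an amine or a carboxylic acid on the same aromatic carbon would give a different number also stays open.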